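This account rests on a few compounds, and the source may have more. Where it says the series, first, only, none or still open, it means among the compounds named here.

In a functional assay on IGROV-1 cells (Homo sapiens) for inhibition, read by sulforhodamine B assay, with a stated time of 48 h (a higher number here means a weaker inhibitor of growth, a lower number a stronger inhibitor of growth), compound 2 `COc1cc2cc(Oc3ccc(NC(=O)Nc4ccc(Cl)c(C(F)(F)F)c4)cc3)c(C)nc2cc1OC` gives 9830 nM, the lowest of the two numbers recorded so far, while compound 1 `COc1cc2cc(Oc3ccc(NC(=O)Nc4cccc(C(F)(F)F)c4)cc3)c(C)nc2cc1OC` gives 24900 nM. For the measured compounds named here, the single measured step between them, a 2.5-fold lower number from compound 1 to compound 2 (0.40 log units; beyond the scatter), is the only comparison at hand. Compound 3 `COc1cc2cc(Oc3ccc(NC(=O)Nc4ccc(Cl)c(Cl)c4)cc3)c(C)nc2cc1OC` differs from compound 2 by chloro in place of trifluoromethyl on an aromatic carbon. Going by the values given here, no measured step exchanges a trifluoromethyl for a chloro, so the step from compound 1 to compound 2 bears on the new change only loosely: it shows that an alteration on this ring can shift the number by a modest amount in this assay. A step of similar or smaller size is therefore expected for compound 3, most likely toward a somewhat higher number, estimated as a 1.4-fold higher number from compound 2 to compound 3 (0.15 log units; within the scatter). On that basis compound 3 is expected to give 14000 nM in this assay, within a range from 5000 nM to 40000 nM.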

Compound 3, concentration for total growth inhibition: 46100 nM
For compound 3 the middle estimate is 3.3-fold (0.52 log units) below the measured one; measured number outside the range, above it.
By their numbers in this assay, from the lowest: compound 2; then compounds 1 and 3 (each within the scatter of the next).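

In this assay, the trifluoromethyl group proves not to be interchangeable with chloro at this place on the ring, ortho to a chloro group: the exchange gives a 4.7-fold higher number from compound 2 to compound 3 (0.67 log units; beyond the scatter), the first step measured at this position. The gain seen when chloro was added, a 2.5-fold lower number from compound 1 to compound 2 (0.40 log units; beyond the scatter), does not carry over once trifluoromethyl is gone, for the 3,4-dichlorophenyl compound stands level with the 3-(trifluoromethyl)phenyl compound, with a 1.9-fold higher number from compound 1 to compound 3 (0.27 log units; within the scatter). Nothing available explains the size of the step from trifluoromethyl to chloro.

Going by these compounds, whether a bromo, a methoxy or a nitrile at this place would behave like trifluoromethyl or like chloro remains open. Also open, on these data alone, is how the same exchange of trifluoromethyl for chloro reads on compound 1, where no second chloro is present.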